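From a 4-methylphenyl to a 4-fluorophenyl group

The source may hold more compounds than are shown below. What is called first, only, known or untested is meant among the compounds shown, and "the series" means these compounds.

In a functional assay on A-431 cells (Homo sapiens) for inhibition, read by MTT assay, with a stated time of 72 h (on this read-out lower numbers stand for stronger inhibition and higher numbers for weaker inhibition), compound 1 (`Fc1ccc(-c2nnc(SCCCN3CCN(c4nc5ccccc5o4)CC3)o2)cc1`) gives 136000 nM and compound 2 (`COc1ccc(-c2nnc(SCCCN3CCN(c4nc5ccccc5s4)CC3)o2)cc1`) gives 56200 nM while compound 3 (`Cc1ccc(-c2nnc(SCCCN3CCN(c4nc5ccccc5s4)CC3)o2)cc1`) gives 61600 nM as its number. Compound 3 thus lies within the scatter of compound 2, and the number of compound 1 stands higher than both, beyond the scatter. Compound 4 (`Fc1ccc(-c2nnc(SCCCN3CCN(c4nc5ccccc5s4)CC3)o2)cc1`) keeps the rest of compound 3 and carries fluoro in place of methyl on an aromatic carbon, para to a large group (fluoro in place of methyl on an aromatic carbon). Within the data shown here, the one measured step at this place, methyl in place of methoxy on an aromatic carbon (a 1.1-fold higher number from compound 2 to compound 3 (0.04 log units; within the scatter)), stayed within the scatter. Among the measured compounds shown here, compound 1 also bears the 4-fluorophenyl group, but it differs from compound 4 elsewhere in the core, so no measured pair isolates fluoro. On this thin evidence, no step beyond the scatter is expected in this assay here. The estimated step is (a 1.1-fold higher number from compound 3 to compound 4 (0.06 log units; within the scatter)) and would stay within the scatter. Compound 4 is estimated at 70000 nM (expected range 35000 nM to 140000 nM).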

Compound 4, half-maximal inhibitory concentration: 67000 nM
Compound 4: middle estimate off by 1.0-fold (0.02 log units), on the high side; low and high end bracket the measured number.
By their numbers in this assay, from the lowest: compounds 2, 3 and 4 (each within the scatter of the next); then compound 1.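

In this assay, fluoro in place of methyl on this aromatic carbon gives a 1.1-fold higher number from compound 3 to compound 4 (0.04 log units; within the scatter) and stays level with the methoxy compound, with a 1.2-fold higher number from compound 2 to compound 4 (0.08 log units; within the scatter) for fluoro in place of methoxy, so methoxy, methyl and fluoro at this place do not separate beyond the scatter. Among these compounds, compound 4 also completes the first pair that isolates a second place, 1,3-benzothiazol-2-yl in place of 1,3-benzoxazol-2-yl on an amine nitrogen in a ring, and a 2.0-fold lower number from compound 1 to compound 4 (0.31 log units; beyond the scatter) is a modest step, the only one here beyond the scatter. No measurement shown accounts for either result.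

As far as these compounds go, whether an amine, a carboxylic acid or a trifluoromethyl group on this aromatic carbon would leave the scatter remains open. The compounds shown carry the change of ring on the amine nitrogen only alongside the 4-fluorophenyl group, so whether it holds with 4-methylphenyl also remains open.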